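The source may report more compounds than this note shows. Statements on the series, on what has been measured and on what is new or still open speak of the compounds shown alone.

Compound 1 `CC1=C(CC/C(C)=C/CC/C(C)=C/CCC2=CC(=O)OC2O)C(C)(C)CCC1=O` and compound 2 `CC(=O)[C@]1(CC/C(C)=C/CC/C(C)=C/CCC2=CC(=O)OC2O)[C@@H](O)CCC1(C)C` are the two measured compounds.

In a functional assay on L5178Y cells (Mus musculus) for cytotoxicity, read by MTT assay (on this read-out higher numbers stand for an effect only at larger amounts of compound and lower numbers for an effect already at smaller amounts), compound 1 reaches only the limit of the measurement, > 10 ug/mL. In this assay compound 2 likewise stops at the limit, > 10 ug/mL. Compound 2 therefore stands at the limit of > 10 ug/mL in this assay, at which 2 of the 2 values shown sit, so no number for it is known, only that its effect appears beyond that amount.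

Compound 3 `CC(=O)[C@]1(CC/C(C)=C/CC/C(C)=C/CCC2=CC(=O)OC2O)[C@H](O)CCC1(C)C` is the unmeasured partner. The change from compound 2 to compound 3 is the two compounds have the same atoms and bonds; at least one stereo element is drawn with a configuration in one of them and without one in the other: 1 of 5 stereo elements differ; a stereocentre at a saturated ring carbon is drawn S in compound 2 and R in compound 3. No step between measured compounds of this kind is shown, so the size of the step from compound 2 to compound 3 in this assay cannot be read from the data; the expectation here is no step beyond the scatter, in either direction, because compound 2 sits at the limit of > 10 ug/mL in this assay, at which 2 of the 2 values shown sit. The step expected for compound 3 is a step that the limit leaves unreadable from compound 2 to compound 3. For compound 3 the estimated value in this assay is 15 ug/mL, within 8 ug/mL to 40 ug/mL.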

Compound 3, concentration for half-maximal effect: 7 ug/mL
Estimate against measurement, compound 3: 2.1-fold (0.33 log units) above, outside the stated range (below it).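

In this assay, within the data shown here, compound 3 gives 7 ug/mL, the only number among the three compounds that is not a limit, so this saturated ring carbon is a place where the configuration alone goes with a readable value. With nothing entering or leaving, the change from S to R gives an at least 1.4-fold lower number from compound 2 to compound 3 (0.15 log units; that floor lies within the scatter). The step can be stated only as a floor because of where compound 2 stands: the limit of > 10 ug/mL in this assay, at which 2 of the 3 values shown sit.

From the compounds shown here alone, how large the step really is stays open, as does whether an amine on this ring carbon, in either configuration, would give a readable number. The comparison also carries a reservation about the drawn structures: the fact that one of compounds 2 and 3 is drawn with a defined configuration and the other without, at the place where they differ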